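A few compounds are considered here, and "the series" means these few. Any claim that something is new, unique, unknown or untested is made for them only; others in the source may bear on it.

Measured in a functional assay (trachea) with Cavia porcellus as the target; a lower number here means a stronger inhibitor, a higher number a weaker inhibitor
compound 1 `CC(C)=CCn1nc(-c2cccnc2)c2ccccc2c1=O` gives 1380 nM
compound 2 `CCOC(=O)CCCn1nc(-c2cccnc2)c2ccccc2c1=O` gives 10000 nM

Compound 2 holds the higher of these two numbers, so it is the weaker of the pair. The next structure, compound 3 `O=C(O)c1ccc(Cn2nc(-c3cccnc3)c3ccccc3c2=O)cc1`, carries 4-carboxyphenyl in place of 2-(ethoxycarbonyl)ethyl on a saturated chain carbon bound to an aromatic nitrogen. The step of a 7.2-fold higher number from compound 1 to compound 2 (0.86 log units; beyond the scatter) is the only one measured at this place, and it was modest and beyond the scatter. Among the measured compounds shown here, no measured compound has a ring on this chain carbon, so that step gives no firm direction for the entering group. In this assay the expected step is a 1.4-fold lower number from compound 2 to compound 3 (0.15 log units; within the scatter) and it is expected to stay within the scatter. For compound 3 the estimate is 7000 nM with an expected range from 1500 nM to 30000 nM on present evidence.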

Compound 3, half-maximal inhibitory concentration: 17000 nM
Estimate against measurement, compound 3: 2.4-fold (0.39 log units) below; the measured number falls inside the stated range.
By their numbers in this assay, from the lowest: compound 1; then compounds 2 and 3 (each within the scatter of the next).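

In this assay, among the compounds shown here, the step of a 1.7-fold higher number from compound 2 to compound 3 (0.23 log units; within the scatter) is the first reading with a ring on this chain carbon, and it leaves 4-carboxyphenyl and 2-(ethoxycarbonyl)ethyl unseparated. For the compounds shown here, the step of a 12-fold higher number from compound 1 to compound 3 (1.09 log units; beyond the scatter) is larger than the one to compound 2 alone and places both oxygen-bearing groups on the same side of compound 1, whose 2-methylprop-1-en-1-yl group carries no oxygen, with neither of the two going against this among the three compounds. No measurement on hand explains these numbers.

On these data alone, it remains open whether the aromatic ring or the carboxylic acid of 4-carboxyphenyl sets the number for compound 3, since plain phenyl and the ethyl ester of 4-carboxyphenyl do not appear here. A free carboxylic acid on the chain of compound 2, a shorter ester chain and an amine at this place are also untested in the compounds shown.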